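Swapping a branched amine for a methylpiperazine ring

The source may report more compounds than this note shows. Statements on the series, on what has been measured and on what is new or still open speak of the compounds shown alone.

Of the compounds shown here, three have so far been measured in an ADME assay on microsomes from liver (Homo sapiens) for metabolic stability, with a stated time of 30 min, tested at 1 uM; on this read-out lower numbers stand for a less stable compound and higher numbers for a more stable compound. Compound 1 `COc1cc(C)c(S(=O)(=O)N(C)CCOCC(=O)N2CCC(C(C)(C)CN(C)C)CC2)c(C)c1` gives 36%, the lowest of the three numbers. Compound 3 `CN(Cc1ccc(C2=NCCN2)cc1)C(=O)COCCN(C)S(=O)(=O)c1ccccc1C(F)(F)F` gives 50%, which lies beyond the usual scatter above compound 1. Compound 2 `COc1cc(C)c(S(=O)(=O)N(C)CCOCC(=O)N2CCN(CC3CCN(C)CC3)CC2)c(C)c1` is built on the same core as compound 1; in this assay compound 2 gives 86%, the furthest from compound 1. Compound 4 `COc1cc(C)c(S(=O)(=O)N(C)CCOCC(=O)N2CCC(CN3CCN(C)CC3)CC2)c(C)c1` is not yet measured. It differs from compound 1 in one place: (4-methylpiperazin-1-yl)methyl in place of 1-((dimethylamino)methyl)-1-methylethyl on a saturated ring carbon. Among the compounds with values here, no measured pair shows this exact change. Because compound 2 gives 86% on the shared core, the step in this assay is expected to run upward, toward more stable, and to exceed the scatter: a number 24 percentage points higher from compound 1 to compound 4 (beyond the scatter). Compound 4 is thus estimated at 60%, within 35% to 85%.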

Compound 4, percent of the compound remaining: 81%
The estimate for compound 4 lay 21 percentage points below the measured number, within the range that was stated.
By their numbers in this assay, from the lowest: compound 1; then compound 3; then compounds 4 and 2 (each within the scatter of the next).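

On a saturated ring carbon of the shared core, (4-methylpiperazin-1-yl)methyl in place of 1-((dimethylamino)methyl)-1-methylethyl gives, in this assay, a number 45 percentage points higher from compound 1 to compound 4 (beyond the scatter). Within the data shown here, this is the first measured pair to isolate a single change, and it shows that the group at this position can have a large effect on the read-out. No evidence on hand explains the step.

The compounds shown leave open which feature of the entering group matters. A morpholine ring or a piperidine ring on the same methyl link could help separate the contributions of the ring and its second nitrogen.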